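The compounds below may be only part of what the source reports. "The series", "measured", "known", "first", "only" and "open" are said of these compounds alone.

Measured in a functional assay on MCF7 cells (Homo sapiens) for cytotoxicity, read by sulforhodamine B assay, with a stated time of 24 h; a lower number here means a stronger inhibitor, a higher number a weaker inhibitor

- compound 1 (`Cc1ccc(/N=C2\C(=O)Nc3ccc(S(=O)(=O)N4CCOCC4)cc32)cc1`) gives 55900 nM
- compound 2 (`COc1ccc(-c2c(C#N)c(N)n(/N=C3\C(=O)Nc4ccc(S(=O)(=O)N5CCOCC5)cc43)c(=O)c2C#N)cc1`) gives 33400 nM
- compound 3 (`O=C1Nc2ccc(S(=O)(=O)N3CCOCC3)cc2/C1=N/c1ccc(/N=C2\C(=O)Nc3ccc(S(=O)(=O)N4CCOCC4)cc32)cc1`) gives 10900 nM

Compound 1 lies within the scatter of compound 2. Compound 3 gives a lower number than compound 1, and that gap lies beyond the scatter. On these numbers, compound 1 stands at the weak end of the small set, together with compound 2.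

The next compound to be tested is compound 4 (`O=C1Nc2ccc(S(=O)(=O)N3CCOCC3)cc2/C1=N/Nc1ccccc1`). It keeps the shared core of compound 1 and carries anilino in place of 4-methylphenyl on a double-bonded nitrogen.

Going by the values given here, no measured pair differs in one place only, so the data offer no direct guide to the size of this step. In this assay, no step beyond the scatter is expected. This expectation rests on indirect evidence only. Compound 2, which carries a much larger group on that nitrogen, gives a number (33400 nM) within the scatter of compound 1. The estimated change is small and lies toward a lower number (a 1.2-fold lower number from compound 1 to compound 4 (0.09 log units; within the scatter)). For compound 4 the expected value is 45000 nM with an estimated range from 15000 nM to 100000 nM.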

Compound 4, half-maximal inhibitory concentration: 30300 nM
Compound 4: the middle estimate sits 1.5-fold (0.17 log units) above what was measured; low and high end bracket the measured number.
By their numbers in this assay, from the lowest: compound 3; then compounds 4, 2 and 1 (each within the scatter of the next).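

Working notes: this is the first single-place step in the series. In this assay, anilino in place of 4-methylphenyl on a double-bonded nitrogen gives a 1.8-fold lower number from compound 1 to compound 4 (0.27 log units; within the scatter), so the exchange stays within the usual scatter even though the entering group brings a hydrogen-bond donor and a hydrogen-bond acceptor that the leaving group lacks, at an equal count of heavy atoms. At this position, then, swapping one aromatic group of this size for the other leaves the read-out essentially unmoved, and compound 4 at 30300 nM cannot be told apart from compound 1 in this assay. Nothing measured on these compounds bears on why the step has this size.

The step joins two changes, the loss of the methyl and the gain of the nitrogen, and a plain phenyl or a 4-methylanilino group on that nitrogen would separate them. Also open, from the compounds shown here alone, is whether a substituent on the anilino ring, such as a carboxylic acid or an amine, would move the number beyond the scatter.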